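The source may report more compounds than this note shows. Statements on the series, on what has been measured and on what is new or still open speak of the compounds shown alone.

Measured compounds:
- compound 1, `c1ccc(Cc2nnc(-c3c[nH]c4ccccc34)o2)cc1` — in a functional assay on PC-3 cells (Homo sapiens) for cytotoxicity, read by MTT assay (a lower number here means a stronger inhibitor, a higher number a weaker inhibitor), compound 1 gives only a limit, > 1000000 nM.
- compound 2, `c1cncc(-c2nnc(-c3c[nH]c4ccccc34)o2)c1` — in this assay compound 2 gives 711000 nM.

Going by the values given here, compound 2 holds the only number in this assay among the two; the value of compound 1 is a limit, (the limit of > 1000000 nM in this assay, at which 1 of the 2 values shown sits). Among the compounds with values here, the one measured step, an at least 1.4-fold lower number from compound 1 to compound 2 (0.14 log units; that floor lies within the scatter), has a floor that lies within the usual scatter, so it tells little about direction.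

Compound 3, `Cc1nnc(-c2c[nH]c3ccccc23)o1`, differs from compound 2 by methyl in place of pyridin-3-yl on an aromatic carbon. Within the data shown here, no measured step covers the loss of a six-membered ring at this place; the step from compound 1 to compound 2 swaps one ring-bearing group for another and does not bear on it directly. Among the measured compounds shown here, with both measured values weak in this assay and the only step inside the scatter, no change beyond the scatter is expected for compound 3, and a limit is as likely as a number.

Compound 3 is therefore estimated at 900000 nM in this assay, with a range from 300000 nM to 3000000 nM. The step from compound 2 to compound 3 is thus expected to be a 1.3-fold higher number from compound 2 to compound 3 (0.10 log units; within the scatter).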

Compound 3, half-maximal inhibitory concentration: > 1000000 nM
Compound 3 gave a limit, no number (the forecaster's own chance of this, stated with the estimate: 50%); middle value at least 1.1-fold (0.04 log units) away from the limit.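

In this assay, methyl in place of pyridin-3-yl on this aromatic carbon, with the loss of the six-membered aromatic ring, gives an at least 1.4-fold higher number from compound 2 to compound 3 (0.14 log units; that floor lies within the scatter); this is a floor and not a size, so the change can be no more than suspected to raise the number. Going by these compounds alone, compound 3 gives only a limit, which brings the series to two such results: the limit of > 1000000 nM in this assay, at which 2 of the 3 values shown sit. The step between compound 1 and compound 3 cannot be read, so methyl and benzyl cannot be ordered at this place, and compound 2, with pyridin-3-yl, remains the only compound with a number, although no printed step sets it beyond the scatter from either of the others.

Still open is whether any group on this carbon of the five-membered aromatic ring can give a step clearly beyond the scatter in this assay, since the three groups shown leave the true size of every step unfixed. An aminomethyl group, a carboxylic acid, a longer alkyl chain or a phenyl ring bound directly to this carbon would each test that, and changes on the rest of the shared core remain a separate question.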